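The source may report more compounds than this note shows. Statements on the series, on what has been measured and on what is new or still open speak of the compounds shown alone.

In an ADME assay on J774 cells (Mus musculus) for cytotoxicity, read by MTT assay, with a stated time of 48 h, tested at 100 ug/mL (a higher number here means a weaker effect of the compound at the concentration tested, a lower number a stronger effect), compound 1, `O=C(N/N=C/c1ccc(Cl)cc1)c1cnccn1`, gives 64%.
Compound 2, `COc1ccc(/C=N/NC(=O)c2cnccn2)cc1`, gives 55%.
Compound 3, `CCOc1ccc(/C=N/NC(=O)c2cnccn2)cc1`, gives 98%.

Compound 3 stands highest of these three numbers. Its nearest neighbour is compound 1, with the step of a number 34 percentage points higher from compound 1 to compound 3 (beyond the scatter), and the furthest is compound 2, with the step of a number 43 percentage points higher from compound 2 to compound 3 (beyond the scatter). The step between the two lower compounds, a number 9 percentage points lower from compound 1 to compound 2 (within the scatter), is within the scatter, so compound 1 and compound 2 cannot be told apart on this assay.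

Compound 4, `N#Cc1ccc(/C=N/NC(=O)c2cnccn2)cc1`, is the next member of the series. It differs from compound 3 by cyano in place of ethoxy on an aromatic carbon.

Among the measured compounds shown here, no measured step exchanges ethoxy for cyano, so the expectation rests on the two steps that arrive at compound 3. Both were large rises when ethoxy replaced a smaller group on the same aromatic carbon, so going the other way, from compound 3 to a compound carrying a smaller group there, is expected to give a large fall. For compound 4 the step expected is therefore a number 36 percentage points lower from compound 3 to compound 4 (beyond the scatter), a value in the region of compound 1 and compound 2. Compound 4 is estimated at 62%, with a range from 38% to 92%.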

Compound 4, a percentage reported as activity, at one concentration (the size of the read-out at that concentration, not a potency): 100%
The estimate for compound 4 lay 38 percentage points below the measured number, and the stated range ends below it.
By their numbers in this assay, from the lowest: compounds 2 and 1 (each within the scatter of the next); then compounds 3 and 4 (each within the scatter of the next).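

In this assay, the step of a number 2 percentage points higher from compound 3 to compound 4 (within the scatter) shows that ethoxy and cyano on this aromatic carbon cannot be told apart, so the high number seen with compound 3 is not peculiar to ethoxy. The remaining two steps, a number 45 percentage points higher from compound 2 to compound 4 (beyond the scatter) and a number 36 percentage points higher from compound 1 to compound 4 (beyond the scatter), show that cyano in place of methoxy or chloro gives a large rise, much as ethoxy did, and the four compounds therefore fall into two pairs: compound 1 with compound 2, and compound 3 with compound 4. The methoxy and ethoxy pair also shows that a shared oxygen on the aromatic carbon does not place two compounds together, and no supporting data bear on what separates the two pairs.

What the compounds shown leave open is where other groups on this carbon would fall, such as an amine, a carboxylic acid or a longer alkoxy chain, and whether any of them would land outside these two pairs. They also leave open whether the same pairing would hold if the shared core were changed elsewhere.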